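Swapping trifluoromethyl for chloro on the urea aryl ring

The source may report more compounds than this note shows. Statements on the series, on what has been measured and on what is new or still open speak of the compounds shown alone.

Compound 1, with the structure `COc1cc2cc(Oc3ccc(NC(=O)Nc4cccc(C(F)(F)F)c4)cc3)c(C)nc2cc1OC`, and compound 2, with the structure `COc1cc2cc(Oc3ccc(NC(=O)Nc4ccc(Cl)c(C(F)(F)F)c4)cc3)c(C)nc2cc1OC`, share one core and differ at a single aromatic carbon. In a functional assay on TK-10 cells (Homo sapiens) for inhibition, read by sulforhodamine B assay, with a stated time of 48 h (a higher number here means that more compound is tolerated, a lower number that less compound is tolerated), compound 1 gives > 50000 nM, which is a limit of the assay rather than a number. In this assay compound 2 gives > 32500 nM, also a limit. The step that the two limits leave unreadable from compound 1 to compound 2 therefore cannot be read, since both values sit at limits: the limit of > 32500 nM in this assay, at which 1 of the 2 values shown sits, and the limit of > 50000 nM in this assay, at which 1 of the 2 values shown sits, mark where the two measured values stand. Within the data shown here, compound 2 thus stands only at a limit, and the one further value shown is a limit too. Compound 3, with the structure `COc1cc2cc(Oc3ccc(NC(=O)Nc4ccc(Cl)c(Cl)c4)cc3)c(C)nc2cc1OC`, is not yet measured; it arises from compound 2 by the change (chloro in place of trifluoromethyl on an aromatic carbon). Among the measured compounds shown here, no measured step bears readably on this change, so no direction can be drawn from compound 1 or compound 2. The expectation is that compound 3 is likewise tolerated up to a limit, with an estimated value of 50000 nM in this assay, ranging from 20000 nM to 100000 nM. This estimate means an expected step that the limit leaves unreadable from compound 2 to compound 3 that is not beyond the scatter.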

Compound 3, concentration lethal to 50% of the cells: 43300 nM
The estimate for compound 3 lay 1.2-fold (0.06 log units) above the measured number; low and high end bracket the measured number.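

In this assay compound 3 gives 43300 nM, the first true number among the compounds shown, so a 3,4-dichlorophenyl group on the urea yields a concentration that can actually be read rather than a limit. Measured against the 3-(trifluoromethyl)phenyl group, the change gives an at least 1.1-fold lower number from compound 1 to compound 3 (0.06 log units; that floor lies within the scatter); only a floor is known here, so the real gap could be small or larger, and this comparison alters two places on the ring rather than one. The direct swap of trifluoromethyl for chloro cannot be read, because compound 2 is known only as a limit: the limit of > 32500 nM in this assay, at which 1 of the 3 values shown sits.

On these data alone, whether chloro in place of trifluoromethyl moves the number on its own therefore stays open, and a true value for compound 2 would be needed to settle it. The compounds shown also leave open how an amine or a carboxylic acid on this same aromatic carbon would read in this assay, so the tolerance of this position to groups other than chloro and trifluoromethyl remains unknown.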